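Fluoro substitution on the benzoyl arm

A few compounds are considered here, and "the series" means these few. Any claim that something is new, unique, unknown or untested is made for them only; others in the source may bear on it.

Two compounds carry measurements in a functional assay on HeLa cells (Homo sapiens) for cytotoxicity, read by MTT assay, with a stated time of 72 h; a lower number here means a stronger inhibitor, a higher number a weaker inhibitor. Compound 1 `CC(=O)OCC(=O)N(/N=N/c1ccc([N+](=O)[O-])cc1Cl)c1ccc([N+](=O)[O-])cc1Cl` gives 350 nM in this assay. Compound 2 `O=C(c1ccccc1)N(/N=N/c1ccc([N+](=O)[O-])cc1C(F)(F)F)c1ccc([N+](=O)[O-])cc1C(F)(F)F` gives 600 nM in this assay; this is the higher of the two numbers, yet its gap to compound 1 lies within the scatter, so no order between them is claimed. Compound 3 `O=C(c1ccc(F)cc1)N(/N=N/c1ccc([N+](=O)[O-])cc1C(F)(F)F)c1ccc([N+](=O)[O-])cc1C(F)(F)F` differs from compound 2 by fluoro in place of hydrogen on an aromatic carbon. Within the data shown here, no step between measured compounds covers this change. Compound 3 is expected to land close to compound 2 in this assay. The step of no change at the digits printed from compound 2 to compound 3 (within the scatter) is expected to stay within the scatter, with no firm direction. The estimate for compound 3 is 600 nM, with a range from 300 nM to 1200 nM.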

Compound 3, half-maximal inhibitory concentration: 1000 nM
Beside the measured number, compound 3's estimate is 1.7-fold (0.22 log units) below it, and the stated range covers the measured number.
By their numbers in this assay, from the lowest: compounds 1, 2 and 3 (each within the scatter of the next, the first and the last beyond it).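

Among these compounds, the first step that changes a single place, phenyl to 4-fluorophenyl, reads a 1.7-fold higher number from compound 2 to compound 3 (0.22 log units; within the scatter) in this assay. Fluoro in place of hydrogen, para to a large group, therefore gives no firm direction at this position. No measurement at hand bears on the reason for this reading.

Still open, on these data alone, is how an amine, a carboxylic acid or a longer chain at this position would read. Compound 1 differs from compound 2 in more than one place, so its acyl arm and its chloro groups cannot be assessed separately.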